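The compounds below may be only part of what the source reports. "The series", "measured", "known", "first", "only" and "open" are said of these compounds alone.

Compound 3, with the structure `O=C1O[C@H]([C@@H](O)Cn2cc(C3CC3)nn2)C(OCc2ccccc2)=C1OCc1ccccc1`, carries a cyclopropyl group on an aromatic carbon of its five-membered ring. In a functional assay on A549 cells (Homo sapiens) for antiproliferative activity, read by MTT assay, with a stated time of 72 h (on this read-out lower numbers stand for stronger inhibition and higher numbers for weaker inhibition), compound 3 gives 43900 nM. Among the three compounds measured so far it is the only one that yields a number at all. Compound 1, with the structure `COc1ccccc1-c1cn(C[C@H](O)[C@H]2OC(=O)C(OCc3ccccc3)=C2OCc2ccccc2)nn1`, reaches only a limit of the assay, > 100000 nM. Compound 2, with the structure `COc1ccc(-c2cn(C/C=C3\OC(=O)C(OCc4ccccc4)=C3OCc3ccccc3)nn2)cc1`, likewise reaches only a limit, > 100000 nM. The measured step from compound 1 to compound 3 is an at least 2.2-fold lower number from compound 1 to compound 3 (0.35 log units; beyond the scatter), so exchanging an aromatic methoxyphenyl group for the small cyclopropyl ring moved the read-out from a limit to a measurable number.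

Compound 4, with the structure `COc1ccc(-c2cn(C[C@H](O)[C@H]3OC(=O)C(OCc4ccccc4)=C3OCc3ccccc3)nn2)cc1`, differs from compound 3 in one place: 4-methoxyphenyl in place of cyclopropyl on an aromatic carbon. This is the reverse of the kind of change seen between compound 1 and compound 3, which went beyond the scatter, and compound 2 with a methoxyphenyl group also sits at the limit of > 100000 nM in this assay, at which 2 of the 3 values shown sit. A step in the opposite direction, toward a higher number, is therefore expected, and compound 4 is expected to return to the limit or close to it, giving an estimated step of a 2.7-fold higher number from compound 3 to compound 4 (0.44 log units; beyond the scatter). The estimate for compound 4 in this assay is 120000 nM, with a range from 50000 nM to 300000 nM.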

Compound 4, half-maximal inhibitory concentration: 28300 nM
Compound 4: middle estimate off by 4.2-fold (0.63 log units), on the high side; the measured number lies below the stated range.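

The step between these two compounds is a 1.6-fold lower number from compound 3 to compound 4 (0.19 log units; within the scatter), so in this assay cyclopropyl and 4-methoxyphenyl cannot be told apart on this aromatic carbon, although the two groups differ in size and in ring type. What changes the read-out is where the methoxy group sits on the phenyl ring, and this could not be seen as a matched comparison before: the step between the two methoxyphenyl compounds is an at least 3.5-fold lower number from compound 1 to compound 4 (0.54 log units; beyond the scatter). A methoxyphenyl group therefore does not fix the outcome on its own, since compound 1 and compound 2 each carry one and still give only a limit of the assay, not a number: the limit of > 100000 nM in this assay, at which 2 of the 4 values shown sit.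

The compounds shown leave open how this same aromatic carbon would respond to a group of another kind, such as a carboxylic acid, an amine or a longer alkyl chain. They also leave open whether any change at this position could give a much lower number than those of compound 3 and compound 4, since only a cyclopropyl ring and methoxyphenyl groups appear there.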